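A few compounds are considered here, and "the series" means these few. Any claim that something is new, unique, unknown or untested is made for them only; others in the source may bear on it.

Compound 3 `COc1ccc(-n2nc(C(=O)Nc3ccc(Oc4ccnc5cc(OCCCN6CCCC6)c(OC)cc45)c(F)c3)c(C)cc2=O)cc1` stands highest of the three numbers recorded in a functional assay on NCI-H460 cells (Homo sapiens) for inhibition, read by MTT assay, with a stated time of 72 h (on this read-out higher numbers stand for weaker inhibition and lower numbers for stronger inhibition), where compound 3 gives 3610 nM. Its nearest neighbour is compound 2 `COc1cc2c(Oc3ccc(NC(=O)c4nn(-c5ccccc5C)c(=O)cc4C)cc3F)ccnc2cc1OCCCN1CCCCC1`, which in this assay gives 3220 nM, a gap within the scatter; furthest away is compound 1 `COc1cc2c(Oc3ccc(NC(=O)c4nn(-c5ccccc5)c(=O)cc4C)cc3F)ccnc2cc1OCCCN1CCCCC1`, which in this assay gives 280 nM, a gap beyond the scatter. Compound 4 `COc1ccc(-n2nc(C(=O)Nc3ccc(Oc4ccnc5cc(OCCCN6CCCCC6)c(OC)cc45)c(F)c3)c(C)cc2=O)cc1` is reached from compound 3 by one change: piperidin-1-yl in place of pyrrolidin-1-yl on a saturated chain carbon, three bonds along the chain from an oxygen on an aromatic ring. Going by the values given here, the only measured step, a 12-fold higher number from compound 1 to compound 2 (1.06 log units; beyond the scatter), concerns a methyl on an aromatic carbon and does not touch the saturated chain, so it does not bear on this change. Among the compounds with values here, compound 1 and compound 4 share the piperidinyl ring but differ elsewhere, so their pair gives no step either. With nothing to go on beyond the ring-size swap itself, the step of a 1.4-fold lower number from compound 3 to compound 4 (0.16 log units; within the scatter) is expected to be small, with no clear direction beyond the scatter. Compound 4 is therefore estimated at 2500 nM in this assay, within a range of 700 nM to 7000 nM.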

Compound 4, half-maximal inhibitory concentration: 3730 nM
The estimate for compound 4 lay 1.5-fold (0.17 log units) below the measured number; low and high end bracket the measured number.
By their numbers in this assay, from the lowest: compound 1; then compounds 2, 3 and 4 (each within the scatter of the next).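

In this assay, piperidin-1-yl in place of pyrrolidin-1-yl at the end of the 3-carbon chain gives a 1.0-fold higher number from compound 3 to compound 4 (0.01 log units; within the scatter), so with the 4-methoxyphenyl group on the aromatic nitrogen, this ring swap leaves no readable difference. The group on that nitrogen now shows a second large step, a 13-fold higher number from compound 1 to compound 4 (1.12 log units; beyond the scatter), while the two substituted phenyl groups cannot be told apart, with a 1.2-fold higher number from compound 2 to compound 4 (0.06 log units; within the scatter), so among these compounds only the unsubstituted phenyl of compound 1 stands apart. No measurement at hand offers a reason for any of these steps.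

On these data alone, whether the ring swap would also read as flat with the unsubstituted phenyl of compound 1 stays open. So does how a morpholine ring at the chain end, or a fluorine on the phenyl, would read.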